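This account rests on a few compounds, and the source may have more. Where it says the series, first, only, none or still open, it means among the compounds named here.

Two compounds share the same core, which carries an amide-type nitrogen bearing a methyl-substituted phenyl ring. Compound 1 `Cc1ccc(NC(=O)c2ccc(/N=N\c3c[nH]c4ccccc34)cc2)cc1` carries a 4-methylphenyl group there, and in a functional assay on HCT-116 cells (Homo sapiens) for inhibition, read by MTT assay, with a stated time of 72 h (on this read-out higher numbers stand for weaker inhibition and lower numbers for stronger inhibition), compound 1 gives 25400 nM. Compound 2 `Cc1ccc(C)c(NC(=O)c2ccc(/N=N\c3c[nH]c4ccccc34)cc2)c1` carries a 2,5-dimethylphenyl group instead; in this assay compound 2 gives 544000 nM, the highest of the two numbers measured, so compound 2 is the weaker inhibitor of the pair. That difference amounts to a 21-fold higher number from compound 1 to compound 2 (1.33 log units; beyond the scatter). Compound 3 `Cc1ccc(NC(=O)c2ccc(/N=N\c3c[nH]c4ccccc34)cc2)c(C)c1` has not yet been measured. It differs from compound 2 in one place: 2,4-dimethylphenyl in place of 2,5-dimethylphenyl on an amide-type nitrogen. Within the data shown here, the only measured step that bears on this change is the one just described, and it shows that moving methyl groups around this ring can shift the number a long way. Compound 3 shares one methyl placement with compound 1 and one with compound 2, so its number is expected to land between theirs, an estimated 3.6-fold lower number from compound 2 to compound 3 (0.56 log units; beyond the scatter) in this assay. Compound 3 is therefore estimated at 150000 nM, within a range from 30000 nM to 600000 nM.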

Compound 3, half-maximal inhibitory concentration: 76100 nM
Compound 3: the middle estimate sits 2.0-fold (0.29 log units) above what was measured; low and high end bracket the measured number.
By their numbers in this assay, from the lowest: compound 1; then compound 3; then compound 2.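

Moving a single methyl group on this ring, with the same atoms in the molecule, gives a 7.1-fold lower number from compound 2 to compound 3 (0.85 log units; beyond the scatter) in this assay, so the number depends on where the methyl groups sit and not only on how many there are. Adding a methyl group to the ring of compound 1 to give the 2,4-dimethylphenyl group gives a 3.0-fold higher number from compound 1 to compound 3 (0.48 log units; beyond the scatter) as a smaller change than a 21-fold higher number from compound 1 to compound 2 (1.33 log units; beyond the scatter) in the same assay, so a second methyl group weakens inhibition by an amount that depends on its placement. No measurement shown here accounts for this difference between the two dimethylphenyl groups.

As far as these compounds go, all three compounds carry only methyl groups on this ring, so it remains open how a plain phenyl ring, or a ring bearing a longer chain such as ethyl, would compare with compound 1. From the compounds shown here alone, it is equally open whether a ring bearing an amine or a carboxylic acid would give a lower number than any seen so far, and whether the order of these three compounds would hold on other cells.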